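Swapping Chloromethyl for Prop-1-en-1-yl on the Amide Carbonyl

The source may report more compounds than this note shows. Statements on the series, on what has been measured and on what is new or still open speak of the compounds shown alone.

Compound 1 `O=C(CCl)N1CCCC(n2nc(-c3ccc(Oc4ccccc4)cc3)cc2CO)C1`, compound 2 `O=C(CCl)Nc1ccc(Cn2nc(-c3ccc(Oc4ccccc4)cc3)cc2CO)cc1` and compound 3 `CCOC(=O)c1cc(-c2ccc(Oc3ccccc3)cc2)nn1Cc1cccc(NC(=O)CCl)c1` were each tested in a functional assay on Z-138 cells (Homo sapiens) for inhibition, read by luminescence and CellTiter-Glo, with a stated time of 72 h; a higher number here means a weaker inhibitor, a lower number a stronger inhibitor. Compound 1 gives 400 nM, compound 2 gives 400 nM, and compound 3 gives 400 nM, so compound 3 sits level with both, and the three cannot be told apart within the scatter. Compound 4 `C/C=C/C(=O)Nc1cccc(Cn2nc(-c3ccc(Oc4ccccc4)cc3)cc2C(=O)OCC)c1` has not yet been measured. It differs from compound 3 in one place: prop-1-en-1-yl in place of chloromethyl on a carbonyl carbon. Within the data shown here, no measured pair shows this change, so its size can only be guessed. A weaker inhibitor is expected, with the step from compound 3 to compound 4 in this assay estimated at a 3.0-fold higher number from compound 3 to compound 4 (0.48 log units; beyond the scatter). Compound 4 is therefore expected to give 1200 nM, within a range from 300 nM to 6000 nM.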

Compound 4, half-maximal inhibitory concentration: 8900 nM
Compound 4: middle estimate off by 7.4-fold (0.87 log units), on the low side; the whole stated range lies below it.
By their numbers in this assay, from the lowest: compounds 1, 2 and 3 (each within the scatter of the next); then compound 4.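

In this assay the group on the amide carbonyl clearly counts: prop-1-en-1-yl in place of chloromethyl brings a 22-fold higher number from compound 3 to compound 4 (1.35 log units; beyond the scatter) and leaves a much weaker inhibitor. Compounds 1, 2 and 3 all carry chloromethyl, so they could not show how much rests on this group. Nothing measured here gives a reason for the loss. Still open, going by these compounds, is how a plain methyl, an ethenyl or a bromomethyl group on the same carbonyl would compare. Also open, on these data alone, is whether the same swap costs as much on the cores of compound 1 and compound 2.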